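Notes on a diarylidene series: compound 2 toward compound 3

The compounds below may be only part of what the source reports. "The series", "measured", "known", "first", "only" and "open" are said of these compounds alone.

Measured compounds:
compound 1 `C=CCn1c(=O)/c(=C\c2ccc(Cl)c(Cl)c2)[nH]c(=O)/c1=C\c1ccccc1` — "not active" (no number reported)
compound 2 `C=CCn1c(=O)/c(=C\c2cccc(F)c2)[nH]c(=O)/c1=C\c1ccccc1OC` — 2500 nM

In a functional assay on U-937 cells (Homo sapiens) for cytotoxicity, read by CCK-8 assay, with a stated time of 72 h (on this read-out higher numbers stand for weaker inhibition and lower numbers for stronger inhibition), compound 2 gives 2500 nM. In this assay compound 1 is reported as "not active" (no number reported), without a number. Among the measured compounds shown here, compound 2 therefore holds the only numerical value shown; its place relative to compound 1 cannot be put into figures, and no step between the two measured compounds is available, as they differ in more than one place.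

The next compound, compound 3 `C=CCn1c(=O)/c(=C\c2ccccc2OC)[nH]c(=O)/c1=C\c1ccccc1OC`, differs from compound 2 by 2-methoxyphenyl in place of 3-fluorophenyl on a double-bonded chain carbon bound to an aromatic carbon. The shared core and the other arylidene arm are unchanged.

For the measured compounds named here, with only one number in hand and no comparable step on record, there is no measured basis for predicting a direction. The expectation is that the step of a 1.4-fold higher number from compound 2 to compound 3 (0.15 log units; within the scatter) lies within the usual scatter or amounts to a small loss at most. For compound 3 the estimated value in this assay is 3500 nM, with a range from 1000 nM to 12000 nM.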

Compound 3, half-maximal inhibitory concentration: 5100 nM
Compound 3: the middle estimate sits 1.5-fold (0.16 log units) below what was measured; the measured number falls inside the stated range.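

In this assay this arylidene position now has its first readable step: 2-methoxyphenyl in place of 3-fluorophenyl gives a 2.0-fold higher number from compound 2 to compound 3 (0.31 log units; beyond the scatter) with the shared core and the other arylidene arm unchanged. The step is modest but beyond the scatter, so the aryl group at this position does register in the read-out, and compound 3 still gives a number with 2-methoxyphenyl on both arms. Nothing on hand bears on why the number moves.

The step exchanges the fluorine for a methoxy group and changes where the substituent sits on the ring in a single move, and the compounds shown do not separate these two changes, while compound 1 carries no number and differs from the others in more than one place, so it cannot extend the comparison. Also open, on these data alone, is how this position would respond to a quite different group on the aryl ring, such as a dimethylamino group or a carboxylic acid, and whether a step of this size would hold with a different arm on the other side.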